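This account rests on a few compounds, and the source may have more. Where it says the series, first, only, none or still open, it means among the compounds named here.

Measured compounds in a functional assay on B16 cells (Mus musculus) for antiproliferative activity, with a stated time of 72 h; a lower number here means a stronger inhibitor, a higher number a weaker inhibitor:
- Compound 1 `OC[C@H]1O[C@@H](n2cnc3c(NCc4ccc(Br)cc4)ncnc32)[C@H](O)[C@@H]1O`: for compound 1 the result > 166000 nM is a limit of the assay, not a number.
- Compound 2 `Cc1ccc(CNc2ncnc3c2ncn3[C@@H]2O[C@H](CO)[C@@H](O)[C@H]2O)cc1`: for compound 2 the entry reads "not determined" (no result reported).
- Compound 3 `COc1cccc(CNc2ncnc3c2ncn3[C@@H]2O[C@H](CO)[C@@H](O)[C@H]2O)c1O`: for compound 3 the result > 166000 nM is likewise a limit of the assay.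

Compound 3 thus stands at the ceiling of this assay, as does compound 1; only compound 2 carries no entry. Among the compounds with values here, the one step with both ends measured, a step that the two limits leave unreadable from compound 1 to compound 3, cannot be read in size, since both ends are limits (the limit of > 166000 nM in this assay, at which 2 of the 3 values shown sit).

Compound 4 `Cc1ccc(O)c(CNc2ncnc3c2ncn3[C@@H]2O[C@H](CO)[C@@H](O)[C@H]2O)c1` differs from compound 3 as 2-hydroxy-5-methylphenyl in place of 2-hydroxy-3-methoxyphenyl on a saturated chain carbon bound to a nitrogen on an aromatic ring. Within the data shown here, no measured step bears on this change with a readable size. The expectation is therefore no shift beyond the scatter, a number no higher from compound 3 to compound 4 (the limit leaves the size open), with compound 4 estimated at 166000 nM (range 50000 nM to 400000 nM), most probably again reported only as a limit.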

Compound 4, half-maximal inhibitory concentration: > 166000 nM
Compound 4 was reported as a limit; the forecaster's own chance of this, stated with the estimate: 75%; the middle value sits exactly at the limit.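

For compound 4 the result > 166000 nM is again a limit. Within the data shown here, no step among compound 1, compound 3 and compound 4 can be read: the limit of > 166000 nM in this assay, at which 3 of the 4 values shown sit. The compounds shown leave open which group at this place, if any, gives a readable half-maximal inhibitory concentration.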